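Aryl hydrazone variation: from compound 3 to compound 4

The source may report more compounds than this note shows. Statements on the series, on what has been measured and on what is new or still open speak of the compounds shown alone.

Three compounds share one core and differ only in the aryl group on the carbon with a double bond to nitrogen. In a functional assay on HT-29 cells (Homo sapiens) for cytotoxicity, read by MTT assay, with a stated time of 72 h (on this read-out higher numbers stand for weaker inhibition and lower numbers for stronger inhibition), compound 1 `CN(C)CCn1cnnc1-c1cc(Oc2ccc(NC(=O)N/N=C/c3c(Cl)cccc3Cl)cc2F)ccn1` gives 280 nM. Compound 2 `COc1cc(/C=N/NC(=O)Nc2ccc(Oc3ccnc(-c4nncn4CCN(C)C)c3)c(F)c2)cc(OC)c1OC` gives 3620 nM in this assay, a change of a 13-fold higher number from compound 1 to compound 2 (1.11 log units; beyond the scatter). Compound 3 `CN(C)CCn1cnnc1-c1cc(Oc2ccc(NC(=O)N/N=C/c3cc(Br)c(O)c(Br)c3)cc2F)ccn1` gives 2670 nM in this assay, which is the second highest of the three numbers; the step of a 1.4-fold lower number from compound 2 to compound 3 (0.13 log units; within the scatter) lies within the scatter, while the step of a 9.5-fold higher number from compound 1 to compound 3 (0.98 log units; beyond the scatter) lies beyond it.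

Compound 4 `CN(C)CCn1cnnc1-c1cc(Oc2ccc(NC(=O)N/N=C/c3ccc(Cl)cc3)cc2F)ccn1` is the next step: 4-chlorophenyl in place of 3,5-dibromo-4-hydroxyphenyl on a carbon with a double bond to nitrogen. Among the measured compounds shown here, no measured step exchanges one halogenated phenyl without a hydroxy group for another. For the measured compounds named here, the steps that bear on it are a 9.5-fold higher number from compound 1 to compound 3 (0.98 log units; beyond the scatter) and a 13-fold higher number from compound 1 to compound 2 (1.11 log units; beyond the scatter), both large and both moving away from compound 1. A partial return toward compound 1 is therefore expected, as a lower number in this assay, by a 3.0-fold lower number from compound 3 to compound 4 (0.47 log units; beyond the scatter). Compound 4 is estimated at 900 nM, with a range from 300 nM to 2700 nM.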

Compound 4, half-maximal inhibitory concentration: 530 nM
Compound 4: the middle estimate sits 1.7-fold (0.23 log units) above what was measured, within the range that was stated.
By their numbers in this assay, from the lowest: compounds 1 and 4 (each within the scatter of the next); then compounds 3 and 2 (each within the scatter of the next).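

In this assay, 4-chlorophenyl is the only replacement for 2,6-dichlorophenyl on this carbon with a double bond to nitrogen that stays within the scatter (a 1.9-fold higher number from compound 1 to compound 4 (0.28 log units; within the scatter)). It also stands clearly apart from both larger groups (a 5.0-fold lower number from compound 3 to compound 4 (0.70 log units; beyond the scatter); a 6.8-fold lower number from compound 2 to compound 4 (0.83 log units; beyond the scatter)), so a low number at this position does not depend on the 2,6-dichlorophenyl pattern, while compounds 2 and 3 go against any reading that every aryl group is tolerated here. Nothing at hand explains these differences.

The compounds shown leave open whether any halogen is needed, which plain phenyl or a 4-aminophenyl or 4-carboxyphenyl group could test. They also do not separate the hydroxy group of compound 3 from its bromines, which a 3,5-dibromophenyl group could address.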